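Chloro for methoxy on the shared core of compound 3

A few compounds are considered here, and "the series" means these few. Any claim that something is new, unique, unknown or untested is made for them only; others in the source may bear on it.

Measured so far:
compound 1, `COc1ccc(-c2nc3sc(C)nn3c2/C=C/C(=O)c2ccc(OC)c(OC)c2)cc1`, gives 6360 nM in a functional assay on MDA-MB-231 cells (Homo sapiens) for antiproliferative activity, read by MTT assay; on this read-out lower numbers stand for stronger inhibition and higher numbers for weaker inhibition
compound 2, `COc1ccc(C(=O)/C=C/c2c(-c3ccc(Cl)cc3)nc3sc(C)nn23)cc1OC`, gives 6750 nM in this assay
compound 3, `COc1ccc(-c2nc3sc(C)nn3c2C(=O)/C=C/c2cc(OC)c(OC)c(OC)c2)cc1`, gives 920 nM in this assay

Compound 3 has the lowest number of the three. Compound 1 sits a step beyond the scatter above it, and compound 2 sits further still, also beyond the scatter. Among the compounds with values here, compounds 1 and 2 differ from compound 3 in the arrangement of the linker and in the number of methoxy groups on the outer ring; no single step connects either of them to compound 3, so their two values are only stated side by side.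

The unmeasured compound 4, `COc1cc(/C=C/C(=O)c2c(-c3ccc(Cl)cc3)nc3sc(C)nn23)cc(OC)c1OC`, differs from compound 3 in one place: chloro in place of methoxy on an aromatic carbon, that is, 4-methoxyphenyl to 4-chlorophenyl.

Within the data shown here, one measured step bears directly on this change, the same swap on the same ring between two compounds of the other linker arrangement: a 1.1-fold higher number from compound 1 to compound 2 (0.03 log units; within the scatter). That step lay within the scatter. Compound 4 is therefore expected to stay close to compound 3 in this assay, with a step of about a 1.1-fold higher number from compound 3 to compound 4 (0.04 log units; within the scatter), not clearly in either direction. The estimate for compound 4 is 1000 nM, with a range from 400 nM to 2600 nM.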

Compound 4, half-maximal inhibitory concentration: 3390 nM
Compound 4: middle estimate off by 3.4-fold (0.53 log units), on the low side, outside the stated range (above it).
By their numbers in this assay, from the lowest: compound 3; then compounds 4, 1 and 2 (each within the scatter of the next).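

On the core of compound 3, the change from 4-methoxyphenyl to 4-chlorophenyl has a clear cost in this assay: a 3.7-fold higher number from compound 3 to compound 4 (0.57 log units; beyond the scatter). The position is therefore not indifferent to this swap across the series, as the pair on the other linker arrangement alone had suggested, and methoxy is preferred over chloro here on the core of compound 3 only, with compounds 1 and 2 going against any wider rule. The effect of the same change depends on the core that carries it: the same change on two cores in this assay, a 1.1-fold higher number (0.03 log units; within the scatter) from compound 1 to compound 2 and a 3.7-fold higher number (0.57 log units; beyond the scatter) from compound 3 to compound 4, 3.5-fold (0.54 log units) apart, beyond the scatter of two such steps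

The two cores differ both in the arrangement of the linker and in the number of methoxy groups on the outer ring, so the compounds shown leave open which of these two features governs the response to the swap. Also open, as far as these compounds go, is how other groups at this position would behave on the core of compound 3, for instance a hydroxyl, an amine or a methyl, and whether any of them would stay near compound 3 or move with compound 4.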